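Inverting the piperidine stereocentre in compound 3

The source may report more compounds than this note shows. Statements on the series, on what has been measured and on what is new or still open speak of the compounds shown alone.

Compound 1: `FC(F)(F)c1cc(NC[C@H]2CCCN2)c2cn[nH]c2c1` with 34%
Compound 2: `FC(F)(F)c1cc(NCC2CNC2)c2cn[nH]c2c1` with 10%
Compound 3: `FC(F)(F)c1cc(NC[C@@H]2CCCCN2)c2cn[nH]c2c1` with 32%

Of the compounds shown here, three have been measured in an assay for inhibition of Indoleamine 2,3-dioxygenase 1 (Homo sapiens), with stated times of 10 min and 60 min, tested at 10 uM; a lower number here means a weaker effect, a higher number a stronger effect of the compound at the concentration tested. Compound 3 `FC(F)(F)c1cc(NC[C@@H]2CCCCN2)c2cn[nH]c2c1` gives 32% and stands second highest of the three; its nearest neighbour is compound 1, and the step from compound 3 to compound 1 lies within the scatter, while the step from compound 2 to compound 3 is a number 22 percentage points higher from compound 2 to compound 3 (beyond the scatter) and lies beyond it.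

Compound 4 `FC(F)(F)c1cc(NC[C@H]2CCCCN2)c2cn[nH]c2c1` is the next compound. Its relation to compound 3 is the two compounds have the same atoms and bonds and differ only in configuration as drawn: 1 of 1 stereo elements differ; a stereocentre at a saturated ring carbon is drawn S in compound 3 and R in compound 4. Going by the values given here, none of the measured steps involves a change of configuration alone: a number 24 percentage points lower from compound 1 to compound 2 (beyond the scatter) and a number 2 percentage points lower from compound 1 to compound 3 (within the scatter) both replace one ring by another, so they do not bear directly on this step. Among the compounds with values here, there is no precedent in these data for what inversion at that carbon does. Compound 4 is therefore expected to stay near compound 3, with a wide range that allows a modest step either way, and the estimated step is a number 4 percentage points lower from compound 3 to compound 4 (within the scatter). The estimate for compound 4 is 28%, from 8% to 48%.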

Compound 4, a percentage reported as inhibition, at one concentration (the size of the read-out at that concentration, not a potency): 19%
For compound 4 the middle estimate is 9 percentage points above the measured one; low and high end bracket the measured number.
By their numbers in this assay, from the lowest: compounds 2 and 4 (each within the scatter of the next); then compounds 3 and 1 (each within the scatter of the next).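

In this assay the configuration at the saturated ring carbon matters in its own right, and a number 13 percentage points lower from compound 3 to compound 4 (beyond the scatter) can be assigned to that stereocentre alone, because nothing else separates the two compounds: the fact that compounds 3 and 4 differ only in the configuration as drawn. The change from pyrrolidin-2-yl to piperidin-2-yl, which lay within the scatter with the S configuration, now gives a number 15 percentage points lower from compound 1 to compound 4 (beyond the scatter) with the R configuration, so the reading of that ring change depends on the configuration drawn. The R configuration also removes the clear separation of piperidin-2-yl from azetidin-3-yl, with a number 9 percentage points higher from compound 2 to compound 4 (within the scatter) as the step.

As far as these compounds go, what inversion would do at the pyrrolidin-2-yl carbon of compound 1 remains open. So does whether either piperidine configuration would hold its value with a methyl group on the ring nitrogen or with a longer chain.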